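Adding an amino group to compound 3

The compounds below may be only part of what the source reports. "The series", "measured", "known", "first", "only" and "open" are said of these compounds alone.

In a physicochemical assay for metabolic stability, read by HPLC, in phosphate buffer, at pH 7.4, tested at 10 uM (on this read-out lower numbers stand for a shorter-lived compound and higher numbers for a longer-lived compound), compound 1 (`O=C(NCCCCc1ccccc1)N1C(=O)c2ccccc2C1=O`) gives 0.1 h. Compound 2 (`O=C(NCCCCc1ccccc1)n1c(=O)n(C(=O)NCCCCc2ccccc2)c2ccccc21`) is reported as > 2 h, which is a limit of the assay and not a number. Compound 3 (`Cc1ccccc1CNC(=O)n1cnc2ccccc21`) gives 0.967 h, the higher of the two actual numbers, and the gap down to compound 1, its nearest neighbour, lies beyond the scatter.

Compound 4 (`Cc1ccccc1CNC(=O)n1c(N)nc2ccccc21`) departs from compound 3 in one place: amino in place of hydrogen on an aromatic carbon. It carries amino in place of hydrogen on an aromatic carbon, between two ring nitrogen atoms and next to the ring atom that bears a large group.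

Going by the values given here, no pair of measured compounds differs in one place only, so the data offer no direct guide to the size of this change. No step beyond the scatter is expected in this assay, and the expectation therefore stays anchored on compound 3 at 0.967 h. The step expected is a 1.4-fold higher number from compound 3 to compound 4 (0.16 log units; within the scatter), and its direction is only tentative. The assay may also report no number but only a limit. For compound 4 the estimated half-life is 1.4 h, with an expected range from 0.5 h to 3.5 h.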

Compound 4, half-life: 0.167 h
Estimate against measurement, compound 4: 8.4-fold (0.92 log units) above, and the stated range ends above it.
By their numbers in this assay, from the lowest: compounds 1 and 4 (each within the scatter of the next); then compound 3. At a limit, above all of these: compound 2.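

Until compound 4, nothing showed how the aromatic carbon between two ring nitrogen atoms responds to a change, and the first single change there proves to matter in this assay: amino in place of hydrogen gives a 5.8-fold lower number from compound 3 to compound 4 (0.76 log units; beyond the scatter). The step lies beyond the scatter, so this position is not a silent one in this assay, even though only one heavy atom enters. The finding rests on this single pair, and nothing measured here says why the number falls at this place.

As far as these compounds go, whether the fall belongs to amino itself or would follow any group on this carbon stays open; a methyl group, a methoxy group or a chlorine atom in the same place would separate those two readings. Also open, from the compounds shown here alone, is whether a substituted amine such as dimethylamino, or an acetylated amino group, would behave as amino does here, and whether the same change would give a step of similar size on a compound with another large group on the neighbouring ring atom.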